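Adding chloro to the 3-chlorophenyl of compound 2

This account rests on a few compounds, and the source may have more. Where it says the series, first, only, none or still open, it means among the compounds named here.

Going by the values given here, compound 2 `Cc1cc(NC(=O)Nc2cccc(Cl)c2)c2ccccc2n1` gives 19000 nM in an ADME assay on HepG2 cells (Homo sapiens) for cytotoxicity, with a stated time of 72 h (on this read-out lower numbers stand for an effect already at smaller amounts and higher numbers for an effect only at larger amounts of compound), the only plain number. Compound 1 `Cc1ccc(NC(=O)Nc2cc(C)nc3ccccc23)cc1` gives > 25000 nM in this assay, a limit. Compound 3 `Cc1cc(NC(=O)Nc2ccc(O)cc2)c2ccccc2n1` likewise gives > 25000 nM in this assay, a limit. Compound 4 `Cc1cc(NC(=O)Nc2cc(Cl)cc(Cl)c2)c2ccccc2n1` is not yet measured; it differs from compound 2 by chloro in place of hydrogen on an aromatic carbon. The measured steps of an at least 1.3-fold lower number from compound 1 to compound 2 (0.11 log units; that floor lies within the scatter) and an at least 1.3-fold higher number from compound 2 to compound 3 (0.11 log units; that floor lies within the scatter) both touch the 3-chlorophenyl, and a step that the two limits leave unreadable from compound 1 to compound 3 adds nothing readable because the limit of > 25000 nM in this assay, at which 2 of the 3 values shown sit, holds both of its ends. Among the compounds with values here, the 3-chlorophenyl thus carries the one readable number, while a second chloro has no measured precedent. The expectation is a step of a 1.6-fold lower number from compound 2 to compound 4 (0.20 log units; within the scatter), within the scatter or a little beyond it toward an effect at smaller amounts. Compound 4 is estimated at 12000 nM, with a range of 4000 nM to 25000 nM, and a fair chance that only a limit is returned.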

Compound 4, half-maximal effective concentration: > 25000 nM
Compound 4 ended at the assay's limit (the forecaster's own chance of this, stated with the estimate: 30%); middle value at least 2.0-fold (0.31 log units) from the limit.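

A second chloro, meta to the first chloro group, brings no readable shift toward an effect at smaller amounts in this assay: the step is an at least 1.3-fold higher number from compound 2 to compound 4 (0.11 log units; that floor lies within the scatter). Going by these compounds alone, until now, this aromatic ring held the only plain number, and chloro in place of hydrogen at this position does not extend that reading to a second compound, although the floor of the step within the scatter leaves its true size unfixed. Within the data shown here, compound 2 remains the only compound with a plain number, and the rest of the series is held at one limit: the limit of > 25000 nM in this assay, at which 3 of the 4 values shown sit.

As far as these compounds go, how far compound 1, compound 3 and compound 4 lie past that limit stays open, so no order among them can be read. Also open, from the compounds shown here alone, is whether an amine or a carboxylic acid at this position would give a plain number.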